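A Second Hydroxymethyl on the Weakest Compound

The source may report more compounds than this note shows. Statements on the series, on what has been measured and on what is new or still open speak of the compounds shown alone.

Compound 1 `Cc1c(CO)cc2n1[C@@H](c1ccccc1)SC2` — 15400 nM
Compound 2 `Cc1cc(CO)c2n1[C@@H](c1ccccc1)SC2` — 63500 nM
Compound 3 `Cc1c(COC(=O)NCc2ccccc2)cc2n1[C@@H](c1ccccc1)SC2` — 8700 nM

In a functional assay on WiDr cells (Homo sapiens) for cytotoxicity, read by MTT assay, with a stated time of 72 h (on this read-out higher numbers stand for weaker inhibition and lower numbers for stronger inhibition), compound 2 gives 63500 nM, the highest of the three numbers. Compound 1 gives 15400 nM and compound 3 gives 8700 nM, both beyond the scatter away from compound 2. Compound 4 `Cc1c(CO)c(CO)c2n1[C@@H](c1ccccc1)SC2` differs from compound 2 by hydroxymethyl in place of hydrogen on an aromatic carbon. Within the data shown here, no step between measured compounds that differ in one place exists to calibrate this change. Compound 1 already carries a hydroxymethyl on the shared core and gives 15400 nM; compound 4 carries both hydroxymethyls at once. The step from compound 2 to compound 4 is expected to be a 3.2-fold lower number from compound 2 to compound 4 (0.50 log units; beyond the scatter), toward stronger inhibition and likely beyond the scatter. Compound 4 is therefore estimated at 20000 nM, within 6000 nM to 60000 nM.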

Compound 4, half-maximal inhibitory concentration: 7100 nM
For compound 4 the middle estimate is 2.8-fold (0.45 log units) above the measured one; low and high end bracket the measured number.
By their numbers in this assay, from the lowest: compounds 4, 3 and 1 (each within the scatter of the next, the first and the last beyond it); then compound 2.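

In this assay, hydroxymethyl in place of hydrogen on an aromatic carbon now has measured steps on the shared core, and both point toward stronger inhibition and lie beyond the scatter: an 8.9-fold lower number from compound 2 to compound 4 (0.95 log units; beyond the scatter) and a 2.2-fold lower number from compound 1 to compound 4 (0.34 log units; beyond the scatter). Compound 4 carries both hydroxymethyl groups, and each one lowers the number when added to the compound bearing the other. Nothing available explains these steps. As far as these compounds go, whether an amine or a carboxylic acid on this aromatic carbon would move the number the same way remains open.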